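A few compounds are considered here, and "the series" means these few. Any claim that something is new, unique, unknown or untested is made for them only; others in the source may bear on it.

Three compounds have numbers in a functional assay on the whole organism (strain albino) for inhibition, with Rattus norvegicus as the target, read by paw edema, with a stated time of 4 h, at a dose of 0.28 mmol/kg by the oral route; a lower number here means less inhibition, a higher number more inhibition at the dose given (going by the name of the read-out). Compound 1 `COc1ccc(-c2nnc(SCC(=O)c3ccccc3)n2-c2ccccc2)cc1OC` gives 65%, compound 2 `O/N=C(/CSc1nnc(-c2ccccc2)n1-c1ccccc1)c1ccccc1` gives 79%, and compound 3 `CCn1c(SCC(=O)c2ccccc2)nnc1-c1ccccc1` gives 63%. Compound 3 thus holds the lowest of the three numbers; its gap to compound 1 lies within the usual scatter, while compound 2 stands beyond the scatter with the higher number. Compound 4 `O=C(CSc1nnc(-c2ccccc2)n1-c1ccccc1)c1ccccc1` has not yet been measured. Its structure differs from compound 3 in one place: phenyl in place of ethyl on an aromatic nitrogen. Among the compounds with values here, no pair of measured compounds isolates this change. Because compound 1 gives 65% close to compound 3 while also carrying a phenyl on the aromatic nitrogen, the step of a number 4 percentage points higher from compound 3 to compound 4 (within the scatter) is expected to stay within the scatter, with no clear direction. Compound 4 is therefore estimated at 67%, with a range from 55% to 78%.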

Compound 4, a percentage reported as inhibition, in the whole organism at one dose (the size of the read-out at that dose, not a potency): 68%
The estimate for compound 4 lay 1 percentage points below the measured number, and the stated range covers the measured number.
By their numbers in this assay, from the lowest: compounds 3, 1 and 4 (each within the scatter of the next); then compound 2.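

In this assay, phenyl in place of ethyl on the aromatic nitrogen gives a number 5 percentage points higher from compound 3 to compound 4 (within the scatter), so this position now has a direct comparison, and the change stays within the scatter. Phenyl in place of 3,4-dimethoxyphenyl on the aromatic carbon gives a number 3 percentage points higher from compound 1 to compound 4 (within the scatter), also within the scatter. Within the data shown here, the only step beyond the scatter is a number 11 percentage points lower from compound 2 to compound 4 (beyond the scatter), a change in the group on the saturated chain carbon bound to sulfur, not on the ring.

From the compounds shown here alone, whether a longer chain such as butyl or an amine on that aromatic nitrogen would keep the number stays open. Nothing available explains any of these steps.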